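Ethenyl-linked chlorophenyl in place of the biaryl: compound 4

This account rests on a few compounds, and the source may have more. Where it says the series, first, only, none or still open, it means among the compounds named here.

Among the compounds with values here, compound 2 `CCOc1cccc(-c2ccc(CN(C(=O)C3CCCCC3)c3cccc(/C=C/C(=O)OC)c3)cc2)c1` gives 147 nM in an assay on isolated protein with Bile acid receptor (Homo sapiens) as the target (a lower number here means that less compound is needed, a higher number that more compound is needed for the effect), the lowest of the three numbers so far; compound 3 `CCOc1cccc(-c2ccc(CN(C(=O)C(C)C)c3cccc(/C=C/C(=O)OC)c3)cc2)c1` sits at 173 nM, within the scatter of it, while compound 1 `COC(=O)/C=C/c1cccc(N(Cc2ccc(/C=C/c3cc(C(F)(F)F)cc(C(F)(F)F)c3)cc2)C(=O)C(C)C)c1` at 1950 nM lies well beyond. Within the data shown here, the only direct step, a 1.2-fold higher number from compound 2 to compound 3 (0.07 log units; within the scatter), concerns the amide side and not the part changed here. Compound 4 `COC(=O)/C=C/c1cccc(N(Cc2ccc(/C=C/c3cccc(Cl)c3)cc2)C(=O)C2CCCCC2)c1` differs from compound 2 by 2-(3-chlorophenyl)ethenyl in place of 3-ethoxyphenyl on an aromatic carbon. Among the measured compounds shown here, no measured step bears on this exchange; compound 1 also carries an ethenyl link, but it differs from compound 2 in the amide and in the ring substituents as well, so its high number is only a loose pointer. The expected step is a 4.1-fold higher number from compound 2 to compound 4 (0.61 log units; beyond the scatter), toward a higher number. Compound 4 is estimated at 600 nM, range 200 nM to 2000 nM.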

Compound 4, half-maximal effective concentration: 165 nM
Compound 4: middle estimate off by 3.6-fold (0.56 log units), on the high side; measured number outside the range, below it.
By their numbers in this assay, from the lowest: compounds 2, 4 and 3 (each within the scatter of the next); then compound 1.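

On this aromatic carbon, para to a large group, 2-(3-chlorophenyl)ethenyl and 3-ethoxyphenyl cannot be told apart in this assay (a 1.1-fold higher number from compound 2 to compound 4 (0.05 log units; within the scatter)). The position thus accepts the ring either directly attached or carried on an ethenyl link, with chlorine in place of the ethoxy oxygen and its carbons in this pair. No evidence is at hand that accounts for this match. The two parts of the exchange remain unseparated: the ethenyl link with the ethoxy group kept, and chlorine on the directly attached ring. On these data alone, how an amine or a carboxylic acid on the terminal ring would read also stays open.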